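This account rests on a few compounds, and the source may have more. Where it says the series, first, only, none or still open, it means among the compounds named here.

Compound 1, `COc1cc(NC(=O)c2cccc(C(F)(F)F)c2)ccc1NS(C)(=O)=O`: > 250000 nM
Compound 2, `CCS(=O)(=O)Nc1ccc(NC(=O)c2cccc(C(F)(F)F)c2)cc1OC`: > 250000 nM

In an ADME assay on HEK293 cells (Homo sapiens) for cytotoxicity, read by MTT assay, with a stated time of 48 h (on this read-out higher numbers stand for weaker inhibition and lower numbers for stronger inhibition), compound 2 gives only a limit of the assay, > 250000 nM, and not a number. Compound 1 likewise gives only a limit in this assay, > 250000 nM. The step that the two limits leave unreadable from compound 1 to compound 2 therefore cannot be read, since both values rest at the limit of > 250000 nM in this assay, at which 2 of the 2 values shown sit.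

Compound 3 `COc1cc(NC(=O)c2cccc(C(F)(F)F)c2)ccc1NS(=O)(=O)C(F)(F)F` has not yet been measured; it differs from compound 2 by trifluoromethyl in place of ethyl on a sulfonyl sulfur. No measured step bears on this change in a readable way: the one step shown, methyl in place of hydrogen on the saturated chain carbon bound to the same sulfonyl sulfur, is hidden by the two limits, so it offers no direction and no size. With both neighbours of the change sitting at the same limit, the step of a number no higher from compound 2 to compound 3 (the limit leaves the size open) is expected to be none beyond the scatter. The estimate for compound 3 in this assay is 250000 nM, with a range from 100000 nM to 1000000 nM, and it is expected that the assay will most likely again report only a limit.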

Compound 3, half-maximal inhibitory concentration: > 250000 nM
Compound 3 was reported as a limit; the forecaster's own chance of this, stated with the estimate: 80%; the middle value lies on the limit itself.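

Compound 3, like compound 1 and compound 2, gives only a limit in this assay and not a number, so no step among these three compounds can be read. Left open is whether methyl, ethyl or trifluoromethyl on the sulfonyl sulfur makes any difference to the reading in this assay at all, as all three compounds share one limit: the limit of > 250000 nM in this assay, at which 3 of the 3 values shown sit.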